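Benzhydryl carbamate to semicarbazide: expected potency change

The source may hold more compounds than are shown below. What is called first, only, known or untested is meant among the compounds shown, and "the series" means these compounds.

In a functional assay on NCI-H460 cells (Homo sapiens) for inhibition, read by MTT assay, with a stated time of 4 days (a lower number here means a stronger inhibitor, a higher number a weaker inhibitor), compound 1 `CCOC(=O)NC(c1ccccc1)c1ccc(Cl)cc1` gives only a limit, > 100000 nM, so its standing rests on the limit of > 100000 nM in this assay, at which 1 of the 2 values shown sits, and no number is fixed for it. Within the data shown here, compound 2 `COc1ccc(C(=NNC(=O)NNC(=O)NCCCC(C)Nc2cc(OC)cc3cccnc23)c2ccc(OC)cc2)cc1` gives 5000 nM in this assay, but it shares little of its structure with compound 1, and no single step joins the two. Compound 3 `NNC(=O)NC(c1ccccc1)c1ccc(Cl)cc1` differs from compound 1 by aminoamino in place of ethoxy on a carbonyl carbon. Among the measured compounds shown here, no measured step covers this change; a step within the scatter is expected, or at most a small one in either direction. Compound 3 is estimated at 100000 nM, with a range of 30000 nM to 300000 nM. The step expected is a number no higher from compound 1 to compound 3 (the limit leaves the size open).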

Compound 3, half-maximal inhibitory concentration: > 100000 nM
Compound 3 ended at the assay's limit (the forecaster's own chance of this, stated with the estimate: 70%); the middle value lies on the limit itself.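

In this assay compound 3 gives > 100000 nM, a limit and not a number. Among these compounds, compound 1 also sits at a limit, so no step from compound 1 to compound 3 can be read. On these data alone, whether aminoamino in place of ethoxy on a carbonyl carbon changes inhibition at all stays open.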